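Two Extra Methyls on the Sulfone Arm of Compound 1

The compounds below may be only part of what the source reports. "The series", "measured", "known", "first", "only" and "open" are said of these compounds alone.

Compound 1 `CNCC(=O)Nc1ccc(-c2nc(CS(C)(=O)=O)cc([C@]34CCOC[C@H]3C4)n2)cc1` is the starting point. In a physicochemical assay for solubility, in phosphate buffer, measured as kinetic solubility, with a stated time of 1 h, at pH 7.4 (on this read-out lower numbers stand for lower solubility and higher numbers for higher solubility), compound 1 gives 158 ug/mL, and compound 2 `Oc1cccc(-c2nccc([C@]34CCOC[C@H]3C4)n2)c1` gives 141 ug/mL; the gap between them lies within the usual scatter, so the two measured compounds cannot be told apart. Compound 3 `CNCC(=O)Nc1ccc(-c2nc(C(C)(C)S(C)(=O)=O)cc([C@]34CCOC[C@H]3C4)n2)cc1` has not been measured. It differs from compound 1 in one place: 1-methyl-1-(methylsulfonyl)ethyl in place of (methylsulfonyl)methyl on an aromatic carbon. Among the compounds with values here, no two measured compounds differ in a single place, so no measured step guides this change. A small downward step in this assay is expected, near the edge of the scatter, giving a 1.6-fold lower number from compound 1 to compound 3 (0.20 log units; within the scatter). Compound 3 is therefore estimated at 100 ug/mL, with a range from 40 ug/mL to 220 ug/mL.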

Compound 3, solubility: 217 ug/mL
Compound 3: middle estimate off by 2.2-fold (0.34 log units), on the low side; measured number inside the range.
By their numbers in this assay, from the lowest: compounds 2, 1 and 3 (each within the scatter of the next).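

Within the data shown here, at this aromatic carbon, in this assay, putting 1-methyl-1-(methylsulfonyl)ethyl in place of (methylsulfonyl)methyl gives a 1.4-fold higher number from compound 1 to compound 3 (0.14 log units; within the scatter) and so offers the first direct look at a change at this position. Compound 1 and compound 3 cannot be told apart on this read-out, so this swap makes no measurable difference. No measured information here bears on the reason for this result. Still open, as far as these compounds go, is whether an amine or a carboxylic acid on this carbon would also stay within the scatter. A single pair also cannot show whether the same swap would behave alike on another core.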